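Swapping an aryl ether for phenethyl: expected permeability

A few compounds are considered here, and "the series" means these few. Any claim that something is new, unique, unknown or untested is made for them only; others in the source may bear on it.

In an ADME assay for permeability, using PAMPA, with a stated time of 30 min, at pH 7.4 (on this read-out higher numbers stand for higher permeability and lower numbers for lower permeability), compound 1 `COc1ccc(-c2ccc3c(NCCCNCc4cccc(OC)c4O)ccnc3c2)cc1` gives 237 10^-6 cm/s and compound 2 `COc1cccc(CNCCCNc2ccnc3cc(-c4ccc(C(C)(C)C)cc4)ccc23)c1O` gives 237 10^-6 cm/s. Compound 3 `COc1ccccc1Oc1ccc2c(NCCCNCc3cccc(OC)c3O)ccnc2c1` gives 317 10^-6 cm/s, the highest of the three numbers, although every gap between them is within the scatter: a 1.3-fold higher number from compound 1 to compound 3 (0.13 log units; within the scatter), a 1.3-fold higher number from compound 2 to compound 3 (0.13 log units; within the scatter), and no change at the digits printed from compound 1 to compound 2 (within the scatter). Compound 4 `COc1cccc(CNCCCNc2ccnc3cc(CCc4ccccc4)ccc23)c1O` differs from compound 3 at a single place: phenethyl in place of 2-methoxyphenoxy on an aromatic carbon. Each of the three measured steps also exchanged a group on that same aromatic carbon, and none of them moved this assay beyond its scatter, so compound 4 is expected to stay close to its neighbours, with a 1.1-fold lower number from compound 3 to compound 4 (0.05 log units; within the scatter) as the expected step. Compound 4 is estimated at 280 10^-6 cm/s, with a range from 170 10^-6 cm/s to 450 10^-6 cm/s.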

Compound 4, apparent permeability in the ADME assay: 23 10^-6 cm/s
Beside the measured number, compound 4's estimate is 12-fold (1.09 log units) above it, outside the stated range (below it).
By their numbers in the ADME assay, from the lowest: compound 4; then compounds 1, 2 and 3 (each within the scatter of the next).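

At this aromatic carbon the group can matter after all: in the ADME assay phenethyl gives a 14-fold lower number from compound 3 to compound 4 (1.14 log units; beyond the scatter), and also a 10-fold lower number from compound 2 to compound 4 (1.01 log units; beyond the scatter) and a 10-fold lower number from compound 1 to compound 4 (1.01 log units; beyond the scatter). Aryl groups joined directly or through an ether oxygen stayed within the scatter of one another, so among these four compounds only compound 4 stands apart. In a physicochemical assay for solubility, with a stated time of 18 h, at pH 7.4 (on this read-out higher numbers stand for higher solubility and lower numbers for lower solubility), compound 3 gives 14500 nM and compound 4 gives 4200 nM, so the same swap also lowers solubility: the measured solubility of compound 3, 14500 nM, and of compound 4, 4200 nM, a 3.5-fold lower number (0.54 log units; beyond the scatter)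

As far as these compounds go, whether these two falls are linked remains open. So does whether a longer chain in place of phenethyl, or an amine on its ring, would give a number nearer compound 3 or nearer compound 4.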